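The source may report more compounds than this note shows. Statements on the series, on what has been measured and on what is new or still open speak of the compounds shown alone.

Measured so far in an assay on HEK293 cells for displacement of a labelled ligand from metabotropic glutamate receptor 5 (Rattus norvegicus); on this read-out lower numbers stand for stronger inhibition and higher numbers for weaker inhibition:
- compound 1 `O=C(Nc1cc(-c2ccccc2)nn1-c1ccccc1)c1cccc([N+](=O)[O-])c1` gives 2220 nM
- compound 2 `O=C(Nc1cc(-c2ccccc2)nn1-c1ccccc1)c1ccc(C(F)(F)F)cc1` gives 990 nM
- compound 3 `Cc1ccc(C(=O)Nc2cc(-c3ccccc3)nn2-c2ccccc2)cc1C` gives 430 nM

Compound 3 stands lowest of the three numbers, with the nearest neighbour compound 2 (a 2.3-fold lower number from compound 2 to compound 3 (0.36 log units; beyond the scatter)) and the furthest compound 1 (a 5.2-fold lower number from compound 1 to compound 3 (0.71 log units; beyond the scatter)). Compound 4 `O=C(Nc1cc(-c2ccccc2)nn1-c1ccccc1)C1=CCCCC1` differs from compound 3 in one place: cyclohex-1-en-1-yl in place of 3,4-dimethylphenyl on a carbonyl carbon. Going by the values given here, every measured step so far swaps one substituted phenyl for another on the carbonyl carbon, for example a 2.2-fold lower number from compound 1 to compound 2 (0.35 log units; beyond the scatter); none of them exchanges the aromatic ring itself for a non-aromatic one, so they bear only loosely on this change. With the best-read ring removed, compound 4 is expected to give a higher number in this assay than compound 3, a step of about a 3.5-fold higher number from compound 3 to compound 4 (0.54 log units; beyond the scatter). The estimate for compound 4 is 1500 nM, within a range of 500 nM to 5000 nM.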

Compound 4, inhibition constant: 4470 nM
Compound 4: middle estimate off by 3.0-fold (0.47 log units), on the low side; low and high end bracket the measured number.
By their numbers in this assay, from the lowest: compound 3; then compound 2; then compounds 1 and 4 (each within the scatter of the next).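

Putting the non-aromatic cyclohex-1-en-1-yl on the carbonyl carbon gives a much weaker result than 3,4-dimethylphenyl (a 10-fold higher number from compound 3 to compound 4 (1.02 log units; beyond the scatter)) and a weaker one than 4-(trifluoromethyl)phenyl (a 4.5-fold higher number from compound 2 to compound 4 (0.65 log units; beyond the scatter)). Against 3-nitrophenyl, however, the exchange cannot be told from scatter (a 2.0-fold higher number from compound 1 to compound 4 (0.30 log units; within the scatter)), so what this ring exchange appears to cost depends on which phenyl group it replaces. Nothing available explains this difference.

Going by these compounds, whether a cyclohexyl ring, a piperidine or an open hexyl chain on the carbonyl carbon would read like cyclohex-1-en-1-yl remains open.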